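The compounds below may be only part of what the source reports. "The series", "measured", "known", "first", "only" and "open" are said of these compounds alone.

The series shares the core of compound 1 `Cc1ccc(Cn2cc(COc3ccc4c(=O)ccoc4c3)nn2)cc1`. In an ADME assay on L02 cells (Homo sapiens) for cytotoxicity, read by MTT assay, with a stated time of 48 h (a higher number here means a weaker inhibitor, a lower number a stronger inhibitor), compound 1 gives only a limit of the assay, > 300000 nM. Compound 2 `O=c1ccoc2cc(OCc3cn(Cc4ccc(Cl)cc4)nn3)ccc12` in this assay also gives only a limit, > 300000 nM. Compound 3 `Cc1ccccc1Cn1cc(COc2ccc3c(=O)ccoc3c2)nn1` in this assay gives a limit as well, > 300000 nM. Going by the values given here, compound 3 thus stands where every value so far stands, namely (the limit of > 300000 nM in this assay, at which 3 of the 3 values shown sit). The steps a step that the two limits leave unreadable from compound 1 to compound 2, a step that the two limits leave unreadable from compound 1 to compound 3 and a step that the two limits leave unreadable from compound 2 to compound 3 are accordingly all of unreadable size. Compound 4 `O=c1ccoc2cc(OCc3cn(Cc4cccc(Cl)c4)nn3)ccc12` differs from compound 3 by 3-chlorophenyl in place of 2-methylphenyl on a saturated chain carbon bound to an aromatic nitrogen. Among the compounds with values here, no measured step gives a readable size for a change of this kind, since all three values sit at the limit. Compound 4 is expected to remain at the limit, with a step that the limit leaves unreadable from compound 3 to compound 4 expected to show no readable size. The estimate for compound 4 is 400000 nM, with a range from 200000 nM to 1000000 nM.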

Compound 4, half-maximal inhibitory concentration: > 300000 nM
Compound 4: a limit, no number; the forecaster's own chance of this, stated with the estimate: 85%; the middle value lies beyond the limit too.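

In this assay compound 4 gives > 300000 nM, a limit and not a number, so its steps from compound 1, compound 2 and compound 3 cannot be read. Left open is whether the four compounds differ at all in this assay.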